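Pyrrolopyrimidine nucleosides: methoxy for dimethylamino step

This account rests on a few compounds, and the source may have more. Where it says the series, first, only, none or still open, it means among the compounds named here.

Measured so far:
- compound 1 `COc1ncnc2c1c(-c1cccs1)cn2[C@@H]1O[C@H](CO)[C@@H](O)[C@H]1O` — 62800 nM
- compound 2 `CN(C)c1ncnc2c1c(-c1cccs1)cn2[C@@H]1O[C@H](CO)[C@@H](O)[C@H]1O` — > 100000 nM
- compound 3 `CN(C)c1ncnc2c1c(-c1cc3ccccc3o1)cn2[C@@H]1O[C@H](CO)[C@@H](O)[C@H]1O` — > 100000 nM

In an ADME assay on BJ cells (Homo sapiens), read by MTT assay, with a stated time of 72 h (a higher number here means a weaker inhibitor, a lower number a stronger inhibitor), compound 1 gives 62800 nM. In this assay compound 2 gives only a limit, > 100000 nM. Compound 3 likewise gives only a limit, > 100000 nM. The change from compound 2 to compound 1 is methoxy in place of dimethylamino on an aromatic carbon; its step is an at least 1.5-fold lower number from compound 2 to compound 1 (0.20 log units; that floor lies within the scatter). The two cores differ as 1-benzofuran-2-yl in place of thiophen-2-yl on an aromatic carbon; that step is a step that the two limits leave unreadable from compound 2 to compound 3, since the limit of > 100000 nM in this assay, at which 2 of the 3 values shown sit, holds both ends.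

Compound 4 `COc1ncnc2c1c(-c1cc3ccccc3o1)cn2[C@@H]1O[C@H](CO)[C@@H](O)[C@H]1O` remains to be measured. It differs from compound 3 by methoxy in place of dimethylamino on an aromatic carbon, the same change as from compound 2 to compound 1, at the same place. The step to expect is therefore estimated as an at least 1.4-fold lower number from compound 3 to compound 4 (0.15 log units; that floor lies within the scatter), resting on the step of an at least 1.5-fold lower number from compound 2 to compound 1 (0.20 log units; that floor lies within the scatter) and on the fact that compound 3 sits at the limit > 100000 nM, so only a lower bound for the size of the earlier step is known. Compound 4 is accordingly estimated at 70000 nM, with a range from 25000 nM to 200000 nM, and a fair chance that this assay again reports only a limit.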

Compound 4, half-maximal inhibitory concentration: 22400 nM
Beside the measured number, compound 4's estimate is 3.1-fold (0.49 log units) above it; the measured number lies below the stated range.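

In this assay, methoxy in place of dimethylamino again goes with a lower number on the core carrying 1-benzofuran-2-yl, with an at least 4.4-fold lower number from compound 3 to compound 4 (0.64 log units; beyond the scatter), so the direction holds on both pairs shown: the same change on two cores in this assay, an at least 1.5-fold lower number (0.20 log units; that floor lies within the scatter) from compound 2 to compound 1 and an at least 4.4-fold lower number (0.64 log units; beyond the scatter) from compound 3 to compound 4; the limit leaves it open whether they differ. Compound 2 and compound 3 both stand at a limit, so neither step has a known full size, and nothing shows that the change carries over with the same size or with a larger one on either core: the limit of > 100000 nM in this assay, at which 2 of the 4 values shown sit. Within the data shown here, with methoxy held in place, 1-benzofuran-2-yl in place of thiophen-2-yl gives a 2.8-fold lower number from compound 1 to compound 4 (0.45 log units; beyond the scatter), the one step here with both ends measured, while the same swap with dimethylamino cannot be read.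

Two pairs leave open whether the direction extends to a core carrying a third group, such as phenyl, in place of thiophen-2-yl or 1-benzofuran-2-yl. Also open, from the compounds shown here alone, is where a smaller amine such as methylamino, or a longer ether such as ethoxy, on that aromatic carbon would fall in this assay.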